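The source may report more compounds than this note shows. Statements on the series, on what has been measured and on what is new or still open speak of the compounds shown alone.

In a functional assay on MCF7 cells (Homo sapiens) for antiproliferative activity, read by MTT assay, with a stated time of 72 h (on this read-out higher numbers stand for weaker inhibition and lower numbers for stronger inhibition), compound 1 `C=CC(=O)Nc1cccc(Oc2nc(Nc3cccc(OC)c3)nc3c2CSCC3)c1` gives > 50000 nM, which is a limit of the assay and not a number. Compound 2 `C/C=C/C(=O)Nc1cccc(Oc2nc(Nc3cccc(OC)c3)nc3c2CSCC3)c1` gives 23400 nM, and compound 3 `CCC/C=C/C(=O)Nc1cccc(Oc2nc(Nc3cccc(OC)c3)nc3c2CSCC3)c1` gives 32000 nM. For the measured compounds named here, these are the only two numbers, and a 1.4-fold higher number from compound 2 to compound 3 (0.14 log units; within the scatter) keeps them level. Compound 4 `C/C=C/C(=O)Nc1cccc(Oc2nc(Nc3ccc(OC)cc3)nc3c2CSCC3)c1` carries 4-methoxyphenyl in place of 3-methoxyphenyl on a nitrogen on an aromatic ring. The measured steps, an at least 2.1-fold lower number from compound 1 to compound 2 (0.32 log units; beyond the scatter) and a 1.4-fold higher number from compound 2 to compound 3 (0.14 log units; within the scatter), change only the group on the carbonyl carbon, so none tests this change. No shift beyond the scatter in this assay is therefore expected, in either direction. The estimated step is a 1.1-fold higher number from compound 2 to compound 4 (0.03 log units; within the scatter). For compound 4 the expected value is 25000 nM, with an estimated range of 10000 nM to 60000 nM.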

Compound 4, half-maximal inhibitory concentration: 24300 nM
Estimate against measurement, compound 4: 1.0-fold (0.01 log units) above; low and high end bracket the measured number.
By their numbers in this assay, from the lowest: compounds 2, 4 and 3 (each within the scatter of the next). At a limit, above all of these: compound 1.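

With 4-methoxyphenyl in place of 3-methoxyphenyl on a nitrogen on an aromatic ring, this assay gives a 1.0-fold higher number from compound 2 to compound 4 (0.02 log units; within the scatter). For the compounds shown here, this is the first measured change away from the carbonyl carbon, and these two placements of the methoxy group are not separated by the read-out. Compound 1 stands at a limit of the assay, which leaves little room above this pair: the limit of > 50000 nM in this assay, at which 1 of the 4 values shown sits.

On these data alone, whether a phenyl bearing an amine or a carboxylic acid on that nitrogen would move the number remains open. Also open, as far as these compounds go, is whether the level step holds with pent-1-en-1-yl on the carbonyl carbon.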